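The source may hold more compounds than are shown below. What is called first, only, known or untested is meant among the compounds shown, and "the series" means these compounds.

Compound 3 (`O=C(NCCCCC(c1ccc(F)cc1)c1ccc(F)cc1)Nc1ccc(Cl)c(C(F)(F)F)c1`) gives 3150 nM in a functional assay on MDA-MB-231 cells (Homo sapiens) for cytotoxicity, read by MTT assay, with a stated time of 48 h (a lower number here means a stronger inhibitor, a higher number a weaker inhibitor), and sits level with compound 2 (`O=C(NCCCCC(c1ccc(F)cc1)c1ccc(F)cc1)Nc1ccc(C(F)(F)F)cc1`), which gives 2780 nM there. The gap of a 1.1-fold higher number from compound 2 to compound 3 (0.05 log units; within the scatter) does not separate the two. Compound 1 (`CC(=O)Nc1ccc(NC(=O)NCCCCC(c2ccc(F)cc2)c2ccc(F)cc2)cc1`) records > 20000 nM as its result, and this is a limit of the assay, not a number.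

Compound 4 (`Nc1cc(NC(=O)NCCCCC(c2ccc(F)cc2)c2ccc(F)cc2)ccc1Cl`) carries amino in place of trifluoromethyl on an aromatic carbon, ortho to a chloro group (amino in place of trifluoromethyl on an aromatic carbon) and meta to a large group.

The closest measured steps run in the opposite direction. Trifluoromethyl in place of acetamido gave an at least 7.1-fold lower number from compound 1 to compound 2 (0.85 log units; beyond the scatter) and 4-chloro-3-(trifluoromethyl)phenyl in place of 4-acetamidophenyl gave an at least 6.3-fold lower number from compound 1 to compound 3 (0.80 log units; beyond the scatter) on the same core. Both steps start from a limit. Among the compounds with values here, compound 1 is the only measured member without trifluoromethyl, and amino is not acetamido, so these steps inform the direction more than the size.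

Part of that gain is expected to be lost, and the estimated change is a 2.5-fold higher number from compound 3 to compound 4 (0.40 log units; beyond the scatter) as a modest move toward a weaker inhibitor. For compound 4 the estimated value is 8000 nM with an expected range from 3000 nM to 20000 nM at this stage.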

Compound 4, half-maximal inhibitory concentration: 9240 nM
Compound 4: middle estimate off by 1.2-fold (0.06 log units), on the low side; the measured number falls inside the stated range.
By their numbers in this assay, from the lowest: compounds 2 and 3 (each within the scatter of the next); then compound 4. At a limit, above all of these: compound 1.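

Within the data shown here, with the chloro group held in place, amino in place of trifluoromethyl gives a 2.9-fold higher number from compound 3 to compound 4 (0.47 log units; beyond the scatter) in this assay, a change confined to this one position, ortho to a chloro group and meta to a large group, which no earlier pair isolated. The 3-amino-4-chlorophenyl group also gives a 3.3-fold higher number from compound 2 to compound 4 (0.52 log units; beyond the scatter) against the 4-(trifluoromethyl)phenyl group, so compound 4 stands apart from both trifluoromethyl members, which lie within the scatter of each other. The remaining step, an at least 2.1-fold lower number from compound 1 to compound 4 (0.33 log units; beyond the scatter), starts from a limit and not a number, and so gives only a bound: the limit of > 20000 nM in this assay, at which 1 of the 4 values shown sits.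

The compounds shown do not tell whether the step follows from the arrival of amino or from the loss of trifluoromethyl, and a methyl, a hydroxyl or a nitrile at this same position would help to separate the two. Also open, on these data alone, is how far the step carries over to a longer chain on the shared core, or to a ring without the chloro group.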